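The compounds below may be only part of what the source reports. "The series", "measured", "known", "first", "only" and "open" are said of these compounds alone.

Measured compounds:
Compound 1 `Cn1c(-c2ccc(NC(=O)CSc3nc4ccccc4o3)cc2)nc(-c2ccccc2)c1-c1ccccc1` — 27.4%
Compound 2 `Cn1c(-c2ccc(NC(=O)CSc3nc4cc(Cl)ccc4o3)cc2)nc(-c2ccccc2)c1-c1ccccc1` — 2.5%
Compound 3 `Cn1c(-c2ccc(NC(=O)CSc3nc4ccccc4s3)cc2)nc(-c2ccccc2)c1-c1ccccc1` — 2.1%

In a functional assay on MCF7 cells (Homo sapiens) for cytotoxicity, read by MTT assay, with a stated time of 24 h, tested at 1.6 ug/mL (a lower number here means a weaker effect, a higher number a stronger effect of the compound at the concentration tested), compound 3 stands lowest of the three numbers. Its nearest neighbour is compound 2, and the step of a number 0.4 percentage points lower from compound 2 to compound 3 (within the scatter) lies within the scatter, so the two cannot be told apart. Its furthest neighbour is compound 1, with the step of a number 25.3 percentage points lower from compound 1 to compound 3 (beyond the scatter) lying beyond the scatter.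

Compound 4 `Cc1nnc(SCC(=O)Nc2ccc(-c3nc(-c4ccccc4)c(-c4ccccc4)n3C)cc2)s1` differs from compound 3 in one place: 5-methyl-1,3,4-thiadiazol-2-yl in place of 1,3-benzothiazol-2-yl on a sulfur. The measured steps that touch the same place are a number 25.3 percentage points lower from compound 1 to compound 3 (beyond the scatter), a modest fall, and a number 0.4 percentage points lower from compound 2 to compound 3 (within the scatter), no change beyond the scatter. These show that swapping the ring on this sulfur can move the number by a modest amount or leave it where it is. Among the compounds with values here, no measured compound carries a five-membered ring with three hetero atoms there, so the direction is uncertain; because compound 3 already gives 2.1%, there is little room for a further fall, and the expected step is a number 7.9 percentage points higher from compound 3 to compound 4 (within the scatter). Compound 4 is therefore estimated at 10%, within a range from 0% to 30%.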

Compound 4, a percentage reported as activity, at one concentration (the size of the read-out at that concentration, not a potency): 37.5%
Estimate against measurement, compound 4: 27.5 percentage points below; the measured number lies above the stated range.
By their numbers in this assay, from the lowest: compounds 3 and 2 (each within the scatter of the next); then compound 1; then compound 4.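

In this assay, changing the group on this sulfur can raise the number as well as lower it, with a number 35.4 percentage points higher from compound 3 to compound 4 (beyond the scatter) and a number 35 percentage points higher from compound 2 to compound 4 (beyond the scatter) as large rises and a number 10.1 percentage points higher from compound 1 to compound 4 (beyond the scatter) as a modest rise. The 5-methyl-1,3,4-thiadiazol-2-yl group has one five-membered aromatic ring and no six-membered ring, yet it gives the highest number of the four compounds, so the six-membered ring of the other three groups is not needed for this effect. No measurement shown here explains this rise.

The compounds shown leave open how much of the rise belongs to the methyl and how much to the ring itself. An amine, a carboxylic acid or a longer chain such as propyl in place of that methyl would help to separate the two.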